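Removing a Trifluoromethyl Group From an Amide Inhibitor

A few compounds are considered here, and "the series" means these few. Any claim that something is new, unique, unknown or untested is made for them only; others in the source may bear on it.

Compound 1 has the structure `COc1cc(-c2nn(-c3cccc(NC(=O)c4cccc(C(F)(F)F)c4)c3)cc2-c2ccncc2)ccc1Cl`. In a functional assay on RPMI-8226 cells (Homo sapiens) for inhibition, read by sulforhodamine B assay, with a stated time of 48 h (on this read-out higher numbers stand for weaker inhibition of growth and lower numbers for stronger inhibition of growth), compound 1 gives 1570 nM, the higher of the two numbers measured here. For the measured compounds named here, the only other measured compound, compound 2, with structure `O=C(Nc1cccc(-n2cc(-c3ccncc3)c(-c3ccc(Cl)c(O)c3)n2)c1)Nc1cc(C(F)(F)F)cc(C(F)(F)F)c1`, gives 477 nM in this assay, a lower number that lies beyond the usual scatter. Compound 2 differs from compound 1 in several places at once, so no single change can be read from that pair. Compound 3, with structure `COc1cc(-c2nn(-c3cccc(NC(=O)c4ccccc4)c3)cc2-c2ccncc2)ccc1Cl`, is not yet measured and differs from compound 1 in one place only: hydrogen in place of trifluoromethyl on an aromatic carbon. Going by the values given here, no measured pair shows this change, so its effect is open. On balance, a modest step toward weaker inhibition, beyond the scatter but not by much, is expected, a 2.2-fold higher number from compound 1 to compound 3 (0.35 log units; beyond the scatter). Compound 3 is therefore estimated to give 3500 nM in this assay, within a range from 1200 nM to 10000 nM.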

Compound 3, concentration for 50% growth inhibition: 850 nM
Compound 3: middle estimate off by 4.1-fold (0.61 log units), on the high side; measured number below the stated range.
By their numbers in this assay, from the lowest: compounds 2, 3 and 1 (each within the scatter of the next, the first and the last beyond it).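

In this assay, hydrogen in place of trifluoromethyl gives a 1.8-fold lower number from compound 1 to compound 3 (0.27 log units; within the scatter), so at this position the step from 3-(trifluoromethyl)phenyl to phenyl cannot be told apart from ordinary repeat-to-repeat variation. On this read-out, then, the trifluoromethyl group is not required for growth inhibition at the level seen with this amide, and the plain benzoyl amide serves as well within the scatter. Nothing measured on these compounds bears on what lies behind this result.

On these data alone, one pair cannot show how far this tolerance extends, so it remains open whether an amine or a carboxylic acid on the same aromatic carbon would also leave the number within the scatter. As far as these compounds go, it also remains open whether the same change would behave alike in compound 2, which carries two trifluoromethyl groups on a urea.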